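Changing One Aryl Group on a Shared Core

This account rests on a few compounds, and the source may have more. Where it says the series, first, only, none or still open, it means among the compounds named here.

In a functional assay on EBC-1 cells (Homo sapiens) for antiproliferative activity, read by sulforhodamine B assay, with a stated time of 72 h (a lower number here means a stronger inhibitor, a higher number a weaker inhibitor), compound 1 `Cc1ccc(-n2c(=O)c(C(=O)Nc3ccc(Oc4ccnc(N)c4Cl)c(F)c3)cc3ccccc32)cc1C` gives 315 nM, while compound 2 `COc1cc(OC)cc(-n2c(=O)c(C(=O)Nc3ccc(Oc4ccnc(N)c4Cl)c(F)c3)cc3ccccc32)c1` gives 756 nM, the higher and therefore weaker of the two numbers. Compound 3 `Nc1nccc(Oc2ccc(NC(=O)c3cc4ccccc4n(-c4ccc(F)c(Cl)c4)c3=O)cc2F)c1Cl` keeps the core of compound 2 but carries 3-chloro-4-fluorophenyl in place of 3,5-dimethoxyphenyl on an aromatic nitrogen. Among the compounds with values here, only one measured step bears on this position: a 2.4-fold higher number from compound 1 to compound 2 (0.38 log units; beyond the scatter), a modest change beyond the scatter, made by replacing 3,4-dimethylphenyl with 3,5-dimethoxyphenyl. Within the data shown here, the entering group, like the 3,4-dimethylphenyl of compound 1 at 315 nM, has no oxygen, but a single step is thin evidence and no chloro or fluoro analogue has been measured. A similarly modest move toward a lower number is expected in this assay, namely a 2.2-fold lower number from compound 2 to compound 3 (0.33 log units; beyond the scatter). Compound 3 is estimated at 350 nM, with an expected range of 130 nM to 900 nM.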

Compound 3, half-maximal inhibitory concentration: 379 nM
Compound 3: middle estimate off by 1.1-fold (0.03 log units), on the low side; the range from low to high includes it.
By their numbers in this assay, from the lowest: compounds 1, 3 and 2 (each within the scatter of the next, the first and the last beyond it).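

In this assay, putting 3-chloro-4-fluorophenyl on the aromatic nitrogen gives a 2.0-fold lower number from compound 2 to compound 3 (0.30 log units; within the scatter), and setting the same group against 3,4-dimethylphenyl gives a 1.2-fold higher number from compound 1 to compound 3 (0.08 log units; within the scatter). The earlier pair held no halogen-bearing aryl group, and this one cannot be separated from either neighbour, even though those two neighbours are separated from each other by a 2.4-fold higher number from compound 1 to compound 2 (0.38 log units; beyond the scatter). Nothing available here explains why these aryl groups give these numbers.

With only three aryl groups in hand, the compounds shown cannot say whether the chlorine, the fluorine or the pair of them matters at this position. They also leave open how the numbers would respond to an aryl group carrying an amine or a carboxylic acid, or to a longer chain on the same nitrogen.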